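Compound 4: a new aryl group on a limited parent

The source may report more compounds than this note shows. Statements on the series, on what has been measured and on what is new or still open speak of the compounds shown alone.

In an ADME assay on KB cells (Homo sapiens) for cytotoxicity, read by MTT assay, with a stated time of 72 h (on this read-out lower numbers stand for stronger inhibition and higher numbers for weaker inhibition), compound 1 `COc1ccc(OC)c(C2=C(c3cc(OC)c(OC)c(OC)c3)C(=O)CC2O[SiH2]C(C)(C)C)c1` gives 10 ug/mL. Compound 2 `COC(=O)c1cc(C2=C(c3cc(OC)c(OC)c(OC)c3)C(=O)CC2O[SiH2]C(C)(C)C)ccc1OC` reaches only a limit of the assay, > 100 ug/mL. Going by these compounds, compound 3 `COc1ccc(C2=C(c3cc(OC)c(OC)c(OC)c3)C(=O)CC2O[SiH2]C(C)(C)C)cc1OC` likewise reaches only a limit, > 100 ug/mL, so its true position remains unknown. Compound 4 `COc1cc(C2=C(c3cc(C)c(OC)c(C)c3)C(O[SiH2]C(C)(C)C)CC2=O)cc(OC)c1OC` departs from compound 3 on a double-bonded ring carbon: 4-methoxy-3,5-dimethylphenyl in place of 3,4-dimethoxyphenyl on a double-bonded ring carbon. Two measured changes at this place bear on it: an at least 10-fold higher number from compound 1 to compound 2 (1.00 log units; beyond the scatter) and an at least 10-fold higher number from compound 1 to compound 3 (1.00 log units; beyond the scatter). Both lead away from the 2,5-dimethoxyphenyl group of compound 1, which compound 4 also lacks. No change beyond the scatter is therefore expected, and the estimated step is a number no higher from compound 3 to compound 4 (the limit leaves the size open). Compound 4 is estimated at 100 ug/mL, with an expected range of 20 ug/mL to 200 ug/mL.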

Compound 4, half-maximal inhibitory concentration: 40 ug/mL
The estimate for compound 4 lay 2.5-fold (0.40 log units) above the measured number, and the stated range covers the measured number.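

In this assay, the change from 2,5-dimethoxyphenyl to 4-methoxy-3,5-dimethylphenyl gives a 4.0-fold higher number from compound 1 to compound 4 (0.60 log units; beyond the scatter), so another group at this double-bonded ring carbon can keep a measurable number. The same new group also separates itself from both groups that had lost activity, with an at least 2.5-fold lower number from compound 3 to compound 4 (0.39 log units; beyond the scatter) and an at least 2.5-fold lower number from compound 2 to compound 4 (0.39 log units; beyond the scatter). The true size of these two steps stays open because compounds 2 and 3 stand at a limit: the limit of > 100 ug/mL in this assay, at which 2 of the 4 values shown sit.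

Going by these compounds, it remains open how an aryl group carrying an amine or a carboxylic acid would behave at this carbon. Whether any group here can pass compound 1 is also unknown.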